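A few compounds are considered here, and "the series" means these few. Any claim that something is new, unique, unknown or untested is made for them only; others in the source may bear on it.

Measured so far:
compound 1 `O=C1N/C(=N\Cc2ccc(C(F)(F)F)cc2)S/C1=C1/CCNC(=O)c2[nH]ccc21` — > 100000 nM
compound 2 `O=C1N/C(=N\Cc2ccc(Cl)cc2)S/C1=C1/CCNC(=O)c2[nH]ccc21` — > 100000 nM
compound 3 `O=C1N/C(=N\Cc2ccccc2Cl)S/C1=C1/CCNC(=O)c2[nH]ccc21` — > 100000 nM

In a functional assay on A549 cells (Homo sapiens) for inhibition, read by MTT assay, with a stated time of 48 h (on this read-out lower numbers stand for stronger inhibition and higher numbers for weaker inhibition), compound 1 gives > 100000 nM, which is a limit of the assay and not a number. In this assay compound 2 likewise gives > 100000 nM, again a limit. Compound 3 gives > 100000 nM in this assay, also a limit. Compound 3 therefore stands at the limit together with the other two, with no number to set it apart, a situation summed up by the limit of > 100000 nM in this assay, at which 3 of the 3 values shown sit.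

The two measured steps, a step that the two limits leave unreadable from compound 1 to compound 2 and a step that the two limits leave unreadable from compound 2 to compound 3, are both unreadable in size, since each joins two limits.

Compound 4 `O=C1N/C(=N\Cc2ccc(F)cc2)S/C1=C1/CCNC(=O)c2[nH]ccc21` is not yet measured. It differs from compound 3 by 4-fluorophenyl in place of 2-chlorophenyl on a saturated chain carbon bound to a double-bonded nitrogen. Within the data shown here, the only steps that bear on this change are the two unreadable ones above, which cover a change on the aromatic ring and a move of the chloro group, and neither gives a size or a direction. No readable step in this series supports an expectation of activity beyond the scatter, so a further limit is the expected outcome. The step that the limit leaves unreadable from compound 3 to compound 4 is thus expected to stay unreadable. Compound 4 is estimated at 150000 nM, within 40000 nM to 500000 nM.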

Compound 4, half-maximal inhibitory concentration: 22400 nM
Estimate against measurement, compound 4: 6.7-fold (0.83 log units) above, and the stated range ends above it.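

In this assay the 4-fluorobenzyl group is the only one of the four benzyl groups shown that gives a number and not a limit of the assay, so the read-out at this place does respond to the aryl group: the limit of > 100000 nM in this assay, at which 3 of the 4 values shown sit.

Fluoro in place of chloro on an aromatic carbon gives an at least 4.4-fold lower number from compound 2 to compound 4 (0.64 log units; beyond the scatter), and exchanging the trifluoromethyl group for fluoro gives an at least 4.4-fold lower number from compound 1 to compound 4 (0.64 log units; beyond the scatter). The full exchange of 2-chlorophenyl for 4-fluorophenyl on a saturated chain carbon bound to a double-bonded nitrogen gives an at least 4.4-fold lower number from compound 3 to compound 4 (0.64 log units; beyond the scatter), and each of these three steps has a limit at one end, so it fixes only a minimum size.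

The steps among compounds 1, 2 and 3 cannot be read, and the compounds shown do not separate the change of halogen from the change of its place on the ring in the step to compound 4. Going by these compounds, whether a methoxy group or an amine on the ring, or a longer chain in place of the benzyl carbon, would also give a number in this assay stays open.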